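This account rests on a few compounds, and the source may have more. Where it says the series, first, only, none or still open, it means among the compounds named here.

The measured compounds and their values:

Compound 1 `N=C(NCCCc1c[nH]cn1)NCCC(c1ccccc1)c1ccccn1` gives 1 in a functional assay on cardiac atrium for agonist activity at histamine H2 receptor (Cavia porcellus); a lower number here means a smaller maximal response, a higher number a larger maximal response.
Compound 2 `N=C(NCCCc1c[nH]cn1)NCCC(c1ccc(F)cc1)c1ccccn1` gives 1.
Compound 3 `N=C(NCCCc1c[nH]cn1)NCCC(c1ccc(Cl)c(Cl)c1)c1ccccn1` gives 1.

Compound 2 stands level with compounds 1 and 3 at the digits shown. Its nearest neighbour is compound 1, with no change at the digits printed from compound 1 to compound 2 (within the scatter), and its furthest is compound 3, with no change at the digits printed from compound 2 to compound 3 (within the scatter); the remaining pair shows no change at the digits printed from compound 1 to compound 3 (within the scatter). All three compounds share the same core, and the three measured steps change only the aryl group on the saturated chain carbon bound to an aromatic carbon and a saturated chain carbon, without moving the maximal response.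

Compound 4 `N=C(NCCCc1c[nH]cn1)NCCC(c1ccccn1)c1ccccn1` is the next member of the series and differs from compound 2 by pyridin-2-yl in place of 4-fluorophenyl on a saturated chain carbon bound to an aromatic carbon and a saturated chain carbon. The change sits at the same place as the three measured steps, each of which stayed within the scatter, so no step beyond the scatter is expected here either. The expected step is no change at the digits printed from compound 2 to compound 4 (within the scatter), that is, none beyond the scatter. Compound 4 is therefore estimated to give 1, with a range from 0.85 to 1.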

Compound 4, intrinsic activity: the largest response reached, as a fraction of the reference agonist's: 1
Compound 4: middle estimate and measured number agree at the digits printed; the measured number falls inside the stated range.
By their numbers in this assay, from the lowest: compounds 1, 2, 3 and 4 (each within the scatter of the next).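

Going by these compounds alone, the pyridin-2-yl group brings the first ring with a hetero atom to this position, on a saturated chain carbon bound to an aromatic carbon and a saturated chain carbon, and the first entering group here with a hydrogen-bond acceptor, yet this assay shows no change at the digits printed from compound 2 to compound 4 (within the scatter) when it replaces 4-fluorophenyl. The same holds against the other two aryl groups, with no change at the digits printed from compound 3 to compound 4 (within the scatter) when it replaces 3,4-dichlorophenyl and no change at the digits printed from compound 1 to compound 4 (within the scatter) when it replaces phenyl, so the maximal response of these four compounds tolerates an aromatic ring of carbon only or one with 1 hetero atom at this place. Nothing in the data shown explains this tolerance.

From the compounds shown here alone, all four compounds keep an aromatic ring at this position, so it remains open whether a saturated cyclohexyl ring, or a ring bearing an amine or a carboxylic acid, would leave the maximal response in this assay where it stands. Going by these compounds, a longer chain between this carbon and the rest of the shared core also remains open, and with every step here within the scatter, the series does not yet show what at this position could lower the response.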